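Replacing bromo with fluoro in compound 3

The compounds below may be only part of what the source reports. "The series", "measured", "known", "first", "only" and "open" are said of these compounds alone.

In a functional assay on A549 cells (Homo sapiens) for antiproliferative activity, read by MTT assay (on this read-out lower numbers stand for stronger inhibition and higher numbers for weaker inhibition), compound 1 `Cn1c(=O)c(=O)n(C2CCCC2)c2nc(N/N=C/c3ccc(O)c(F)c3)ncc21` gives 97800 nM, compound 2 `Cn1c(=O)c(=O)n(C2CCCC2)c2nc(N/N=C/c3ccc(F)cc3Cl)ncc21` gives 11000 nM and compound 3 `Cn1c(=O)c(=O)n(C2CCCC2)c2nc(N/N=C/c3ccc(F)cc3Br)ncc21` gives 6590 nM. Compound 3 thus stands with compound 2 at the low end of these numbers, the two lying within the scatter of each other. Both lie clearly apart from compound 1, with an 8.9-fold lower number from compound 1 to compound 2 (0.95 log units; beyond the scatter) and a 15-fold lower number from compound 1 to compound 3 (1.17 log units; beyond the scatter). Compound 4 `Cn1c(=O)c(=O)n(C2CCCC2)c2nc(N/N=C/c3ccc(F)cc3F)ncc21` differs from compound 3 by fluoro in place of bromo on an aromatic carbon, which turns 2-bromo-4-fluorophenyl into 2,4-difluorophenyl. The closest measured change at this place is a 1.7-fold lower number from compound 2 to compound 3 (0.22 log units; within the scatter), bromo in place of chloro, and it stayed within the scatter. The steps from compound 1 alter a different substitution pattern and bear on this change only loosely. No fluoro at this place has been measured, so the expectation is uncertain. The expected change in this assay is a 1.7-fold higher number from compound 3 to compound 4 (0.22 log units; within the scatter), leaning slightly towards a higher number and not clearly beyond the scatter. For compound 4 the estimated value is 11000 nM, with an expected range of 4500 nM to 30000 nM.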

Compound 4, half-maximal inhibitory concentration: 18300 nM
Beside the measured number, compound 4's estimate is 1.7-fold (0.22 log units) below it; low and high end bracket the measured number.
By their numbers in this assay, from the lowest: compounds 3, 2 and 4 (each within the scatter of the next, the first and the last beyond it); then compound 1.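

Fluoro in place of bromo at this position gives a 2.8-fold higher number from compound 3 to compound 4 (0.44 log units; beyond the scatter) in this assay, so a swap between halogens at this place can move the number beyond the scatter, which the step between chloro and bromo did not show. Fluoro in place of chloro, by contrast, gives a 1.7-fold higher number from compound 2 to compound 4 (0.22 log units; within the scatter) and does not separate the two, so only the bromo and fluoro compounds can be told apart. The 2,4-difluorophenyl group also stays clearly apart from 3-fluoro-4-hydroxyphenyl, with a 5.3-fold lower number from compound 1 to compound 4 (0.73 log units; beyond the scatter) on that exchange. Nothing given here accounts for these differences. Still open, as far as these compounds go, is how a group other than a halogen, such as methoxy, an amine or a nitrile, would read at this place. Also open, from the compounds shown here alone, is whether the gap between bromo and fluoro persists when the 4-fluoro group is exchanged.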